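Propyl Ketone to Isopropyl Amide on a Shared Core

A few compounds are considered here, and "the series" means these few. Any claim that something is new, unique, unknown or untested is made for them only; others in the source may bear on it.

Compound 1 `CCCC(=O)C1=C(C)NC(=O)NC1c1ccco1` is one of three close relatives that differ only in the aromatic ring attached to a saturated ring carbon of the shared core. In an assay on membranes from HeLa cells for displacement of a labelled ligand from adenosine receptor A3 (Homo sapiens), read by scintillation counting, with a stated time of 180 min, tested at 1 uM (a higher number here means more inhibition at the concentration tested (going by the name of the read-out), a lower number less inhibition), compound 1 gives 1%, the lowest of the three numbers shown, although the gap to the others is within the scatter: compound 2 `CCCC(=O)C1=C(C)NC(=O)NC1c1ccoc1` gives 2% and compound 3 `CCCC(=O)C1=C(C)NC(=O)NC1c1cccs1` gives 2%. The steps of a number 1 percentage points higher from compound 1 to compound 2 (within the scatter), a number 1 percentage points higher from compound 1 to compound 3 (within the scatter) and no change at the digits printed from compound 2 to compound 3 (within the scatter) are all within the scatter, so all three sit at essentially no inhibition. Compound 4 `CC1=C(C(=O)NC(C)C)C(c2ccco2)NC(=O)N1` alters a different part: isopropylamino in place of propyl on a carbonyl carbon. Among the measured compounds shown here, no measured step touches this carbonyl carbon, so there is no direct guide. The expected step is a number 2 percentage points higher from compound 1 to compound 4 (within the scatter), because compound 1 itself shows only 1%. Compound 4 is estimated at 3%, with a range from -5% to 14%.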

Compound 4, a percentage reported as inhibition, at one concentration (the size of the read-out at that concentration, not a potency): 4%
Compound 4: the middle estimate sits 1 percentage points below what was measured; measured number inside the range.
By their numbers in this assay, from the lowest: compounds 1, 2, 3 and 4 (each within the scatter of the next).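

Among the compounds shown here, this is the first look at the carbonyl carbon, and in this assay isopropylamino in place of propyl gives a number 3 percentage points higher from compound 1 to compound 4 (within the scatter). Compound 4 therefore sits at essentially no inhibition, like the three compounds that vary the aromatic ring, even though the change brings in an amide hydrogen. No measurement at hand explains this result.

Still open, from the compounds shown here alone, is whether a longer chain on the amide nitrogen, a cyclic amine such as piperidine, or a carboxylic acid at this carbonyl carbon would lift the number beyond the scatter.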